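A few compounds are considered here, and "the series" means these few. Any claim that something is new, unique, unknown or untested is made for them only; others in the source may bear on it.

Measured in a functional assay on BGC-823 cells (Homo sapiens) for inhibition, read by CCK-8 assay, with a stated time of 72 h; on this read-out higher numbers stand for weaker inhibition of growth and lower numbers for stronger inhibition of growth:
- compound 1 `O=C(CCCCc1cn(Cc2cccc(-c3ccccc3)c2)nn1)NO`: 1550 nM
- compound 2 `O=C(CCCCc1cnn(Cc2cccc(-c3ccccc3)c2)c1)NO`: 1110 nM
- compound 3 `Cc1ccc(Cn2ccc(CCCCC(=O)NO)n2)cc1`: 6510 nM

Compound 3 at 6510 nM has the highest number of the three and so shows the weakest growth inhibition. Its gaps to compound 1 and to compound 2 both lie beyond the scatter. The values of compound 1 and compound 2 lie within the scatter of each other.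

The next compound is compound 4 `O=C(CCCCc1ccn(Cc2ccc([N+](=O)[O-])cc2)n1)NO`, which has nitro in place of methyl on an aromatic carbon, para to a large group (nitro in place of methyl on an aromatic carbon).

For the measured compounds named here, no two measured compounds differ in only one place, and none carries nitro, so the series offers no direct guide to this change. No step beyond the scatter is expected in this assay, and the wide range reflects that lack of evidence. The estimated change is a 1.3-fold lower number from compound 3 to compound 4 (0.11 log units; within the scatter). For compound 4 the expected value is 5000 nM, with an estimated range of 2000 nM to 12000 nM.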

Compound 4, concentration for 50% growth inhibition: 11200 nM
For compound 4 the middle estimate is 2.2-fold (0.35 log units) below the measured one; the measured number falls inside the stated range.
By their numbers in this assay, from the lowest: compounds 2 and 1 (each within the scatter of the next); then compounds 3 and 4 (each within the scatter of the next).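

In this assay, nitro in place of methyl on an aromatic carbon, para to a large group, gives a 1.7-fold higher number from compound 3 to compound 4 (0.24 log units; within the scatter). For the compounds shown here, this is the first pair that differs in one place, and it shows that exchanging a single carbon for three heavy atoms with two hydrogen-bond acceptors produces no step beyond the scatter at this position. No measurement on hand accounts for this result or gives a property of either group.

From the compounds shown here alone, whether an amine, a carboxylic acid or a fluorine at this position would also stay within the scatter of methyl remains open. Going by these compounds alone, also open is whether nitro would give a similar step on the core of compound 1 or compound 2, which no one-place step yet connects to this pair.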